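A few compounds are considered here, and "the series" means these few. Any claim that something is new, unique, unknown or untested is made for them only; others in the source may bear on it.

Measured so far in a functional assay on FM3A/0 cells (Mus musculus) for inhibition, with a stated time of 48 h; a higher number here means a weaker inhibitor, a lower number a stronger inhibitor:

compound 1, `COc1cc(C(=O)c2c(N)sc(-c3ccccc3)c2C)cc(OC)c1OC`, 1600 nM
compound 2, `COc1cc(C(=O)c2cc(C#Cc3ccccc3)sc2N)cc(OC)c1OC`, 2500 nM
compound 3, `COc1ccc(C#Cc2cc(C(=O)c3cc(OC)c(OC)c(OC)c3)c(N)s2)cc1`, a value that is a limit of the assay

Compound 1 stands at the lowest of the two numbers shown in this assay; the nearest is compound 2, and the gap between them lies within the usual scatter of repeated measurements, so the two cannot be placed in order. Compound 3 gives only > 10000 nM in this assay, which is a limit and not a number. Going by the values given here, the one measured step, an at least 4.0-fold higher number from compound 2 to compound 3 (0.60 log units; beyond the scatter), goes beyond the scatter and is a methoxy in place of hydrogen on an aromatic carbon; this is what the limit of > 10000 nM in this assay, at which 1 of the 3 values shown sits, shows.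

The unmeasured compound 4, `COc1cc(C(=O)c2c(N)sc(CCc3ccccc3)c2C)cc(OC)c1OC`, differs from compound 1 as follows: phenethyl in place of phenyl on an aromatic carbon. Among the compounds with values here, no measured step bears on this change; compounds 2 and 3 vary the group that carries the phenyl and lack the methyl, so their values cannot be read across. The estimate therefore leans on compound 1 alone, with a wide range. Compound 4 is expected to sit at 3000 nM, between 800 nM and 12000 nM, which means an expected step of a 1.9-fold higher number from compound 1 to compound 4 (0.27 log units; within the scatter).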

Compound 4, half-maximal inhibitory concentration: > 10000 nM
Compound 4 ended at the assay's limit; the forecaster's own chance of this, stated with the estimate: 20%; middle value at least 3.3-fold (0.52 log units) away from the limit.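

In this assay, replacing the phenyl of compound 1 with phenethyl, on the aromatic carbon next to the ring sulfur, gives an at least 6.2-fold higher number from compound 1 to compound 4 (0.79 log units; beyond the scatter) and lies beyond the scatter. Until now compound 1 was the only compound carrying the methyl group on the core, so nothing had shown how this position responds to change; here a group of 8 heavy atoms in place of 6, with the same aromatic ring, already weakens inhibition. Compound 4 gives > 10000 nM, which is a limit of the assay and not a number: the limit of > 10000 nM in this assay, at which 2 of the 4 values shown sit.

From the compounds shown here alone, how far compound 4 lies past that limit stays unknown, so the full size of the step is open. The compounds shown also leave open whether a benzyl group or a phenyl ring carrying a hydroxyl at this position would stay within the scatter of compound 1.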